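The source may report more compounds than this note shows. Statements on the series, on what has been measured and on what is new or still open speak of the compounds shown alone.

Compound 2 `O=C(Nc1ccc(OC(F)F)cc1)c1cccc(/C=C2\CC(=O)N(c3ccccc3)C2=O)c1` is reported in an ADME assay on HCT-116 cells (Homo sapiens) for cytotoxicity, read by MTT assay, with a stated time of 72 h (on this read-out lower numbers stand for stronger inhibition and higher numbers for weaker inhibition), only as a limit of the assay, > 100000 nM. Compound 1 `CCCCCN1C(=O)C/C(=C\c2cccc(C(=O)Nc3ccc(C)cc3)c2)C1=O` likewise returns in this assay only a limit, > 100000 nM. Among the measured compounds shown here, every value shown therefore sits at the limit of > 100000 nM in this assay, at which 2 of the 2 values shown sit, and compound 2 cannot be placed above or below any other entry; no measured step exists within this set. Compound 3 `O=C(NCC1CCCCC1)c1cccc(/C=C2\CC(=O)N(c3ccccc3)C2=O)c1` differs from compound 2 by cyclohexylmethyl in place of 4-(difluoromethoxy)phenyl on an amide-type nitrogen. For the measured compounds named here, with both values shown resting at the same limit, there is no measured step from which to read a size or a direction for this change; the expectation in this assay is a step of none beyond the scatter, a step that the limit leaves unreadable from compound 2 to compound 3, with the result most likely returned again as a limit rather than a number. For compound 3 in this assay the estimate is 150000 nM, within 30000 nM to 600000 nM.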

Compound 3, half-maximal inhibitory concentration: > 100000 nM
Compound 3 ended at the assay's limit; the forecaster's own chance of this, stated with the estimate: 75%; the middle value lies beyond the limit too.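

No step can be read from compound 2 to compound 3 in this assay, since both return only a limit: the limit of > 100000 nM in this assay, at which 3 of the 3 values shown sit.

On these data alone, whether cyclohexylmethyl in place of 4-(difluoromethoxy)phenyl on an amide-type nitrogen changes the read-out in this assay at all, and whether any compound of this series gives a measurable value there, stays open.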